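The compounds below may be only part of what the source reports. "The series", "measured", "known", "first", "only" and "open" are said of these compounds alone.

Measured compounds and their values in a functional assay on HCT-116 cells (Homo sapiens) for cytotoxicity, read by sulforhodamine B assay, with a stated time of 48 h; on this read-out higher numbers stand for weaker inhibition and lower numbers for stronger inhibition:

Compound 1, `Cc1ccc(-c2c(S(=O)(=O)c3ccccc3)cnc3cc(-c4ccccc4)nn23)cc1`, gives 18 ug/mL.
Compound 2, `Cc1ccc(-c2c(S(=O)(=O)c3ccccc3)cnc3cc(-c4ccc(Cl)cc4)nn23)cc1`, gives 9.3 ug/mL.
Compound 3, `O=S(=O)(c1ccccc1)c1cnc2ncnn2c1-c1ccccc1`, gives 1.97 ug/mL.

Compound 1 and compound 2 share one core and differ in a single spot: chloro in place of hydrogen on an aromatic carbon. That change made a step of a 1.9-fold lower number from compound 1 to compound 2 (0.29 log units; within the scatter), so within the usual spread of repeated measurements nothing can be said about a direction between these two.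

Compound 3 is built on a different core, and the difference between the two cores is not broken down here. Compound 3 stands apart from the other two in this assay, with numbers from compound 2 and compound 1 lying beyond the scatter above it.

Compound 4, `O=S(=O)(c1ccccc1)c1cnc2ncnn2c1-c1ccc(Cl)cc1`, is not yet measured. It arises from compound 3 by the same change that leads from compound 1 to compound 2: chloro in place of hydrogen on an aromatic carbon. The surroundings of the spot are described in the same words in both cases.

Within the data shown here, the only guide to what that change does is the step seen between compound 1 and compound 2, which was small, and it was seen on a different core. The expected step from compound 3 to compound 4 is therefore a 1.5-fold lower number from compound 3 to compound 4 (0.18 log units; within the scatter), a small one resting on the step of a 1.9-fold lower number from compound 1 to compound 2 (0.29 log units; within the scatter). Compound 4 is estimated at 1.3 ug/mL, expected to fall between 0.5 ug/mL and 3.5 ug/mL.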

Compound 4, half-maximal inhibitory concentration: 2.15 ug/mL
Compound 4: the middle estimate sits 1.7-fold (0.22 log units) below what was measured; low and high end bracket the measured number.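

On the core of compound 3, putting chloro in place of hydrogen, which turns phenyl into 4-chlorophenyl, gave in this assay a 1.1-fold higher number from compound 3 to compound 4 (0.04 log units; within the scatter), so compound 3 and compound 4 cannot be told apart in this test. Set beside the same change on the core of compound 1, the two steps do not differ by more than repeated measurements would: the same change on two cores in this assay, a 1.9-fold lower number (0.29 log units; within the scatter) from compound 1 to compound 2 and a 1.1-fold higher number (0.04 log units; within the scatter) from compound 3 to compound 4, 2.1-fold (0.32 log units) apart, within the scatter of two such steps

This shows that the change stayed small on both cores, so nothing here speaks against carrying it from one core to the other, but it does not show that chloro acts in the same way on each, as neither step is large enough to give a readable direction and two cores make a very small sample.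

What the compounds shown leave open is whether a different group on that same aromatic carbon, such as an amine, a methoxy group or a carboxylic acid, would give a step beyond the scatter on either core. They also leave open which parts of the two cores account for the gap between compound 3 and compound 1, as those two differ in more than one place.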